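Swapping the aryl group on a shared amide core

The compounds below may be only part of what the source reports. "The series", "measured", "known", "first", "only" and "open" are said of these compounds alone.

Compound 1 `Cc1cc(NC(=O)Cn2nnc(-c3cccc(Cl)c3)n2)n(C2CCCCC2)n1` and compound 2 `Cc1cc(NC(=O)Cn2nnc(-c3ccnc(F)c3)n2)n(C2CCCCC2)n1` share one core and differ only in the aromatic group on the five-membered ring. In an assay on HEK293 cells for activation of Kir3.1/Kir3.2 (Homo sapiens), read by thallium flux (on this read-out higher numbers stand for an effect only at larger amounts of compound and lower numbers for an effect already at smaller amounts), compound 1 gives 300 nM and compound 2 gives 441 nM; the two numbers sit alongside each other, since the step of a 1.5-fold higher number from compound 1 to compound 2 (0.17 log units; within the scatter) falls within the scatter. Compound 3 `Cc1cc(NC(=O)Cn2nnc(-c3ccc(C(F)(F)F)cc3)n2)n(C2CCCCC2)n1` differs from compound 2 by 4-(trifluoromethyl)phenyl in place of 2-fluoropyridin-4-yl on an aromatic carbon. Within the data shown here, only that one earlier step bears on this change, and it was within the scatter, so no step beyond the scatter is expected in this assay. Compound 3 is therefore estimated at 380 nM, within 150 nM to 950 nM, an expected step of a 1.2-fold lower number from compound 2 to compound 3 (0.06 log units; within the scatter).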

Compound 3, half-maximal effective concentration: 241 nM
Estimate against measurement, compound 3: 1.6-fold (0.20 log units) above; low and high end bracket the measured number.
By their numbers in this assay, from the lowest: compounds 3, 1 and 2 (each within the scatter of the next).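

In this assay, the position on the aromatic carbon of the five-membered ring now carries three different aromatic groups with no step beyond the scatter: a 1.8-fold lower number from compound 2 to compound 3 (0.26 log units; within the scatter) and a 1.2-fold lower number from compound 1 to compound 3 (0.10 log units; within the scatter). The entering 4-(trifluoromethyl)phenyl has a ring of carbon only and 0 hydrogen-bond acceptors, yet trading the 2-fluoropyridin-4-yl for it leaves the number within the scatter. Nothing measured here offers an explanation for this result. Going by these compounds, whether an amine, a carboxylic acid or a non-aromatic ring at this position would also stay within the scatter remains open.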